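Ring substituent swap on the anilino group in MV4-11 series

A few compounds are considered here, and "the series" means these few. Any claim that something is new, unique, unknown or untested is made for them only; others in the source may bear on it.

Compound 1 `Cc1n[nH]c2ccc(-c3nc4cnc(N5CCN(C)CC5)cn4c3Nc3ccc(Cl)cc3)cc12` gives 83.7% in a functional assay on MV4-11 cells (Homo sapiens) for inhibition, with a stated time of 120 h, tested at 10 uM; a higher number here means more inhibition at the concentration tested (going by the name of the read-out), a lower number less inhibition. For the measured compounds named here, compound 2 `Cc1n[nH]c2ccc(-c3nc4cnc(N5CCN(C)CC5)cn4c3Nc3ccc(Cl)cc3F)cc12` gives 0% in this assay, the lowest of the two numbers in hand; the only measured step, a number 83.7 percentage points lower from compound 1 to compound 2 (beyond the scatter), is fluoro in place of hydrogen on an aromatic carbon. Compound 3 `Cc1n[nH]c2ccc(-c3nc4cnc(N5CCN(C)CC5)cn4c3Nc3ccc(Cl)cc3Cl)cc12` is not yet measured; it differs from compound 2 by chloro in place of fluoro on an aromatic carbon. Going by the values given here, no measured step exchanges fluoro for chloro, so the expectation rests on the single step from compound 1 to compound 2 alone, where adding a group at this position removed inhibition entirely. A chloro group at the same position is expected to leave compound 3 near compound 2, so the estimated step is a number 10 percentage points higher from compound 2 to compound 3 (within the scatter), within the scatter or a small rise at most. Compound 3 is therefore estimated at 10% in this assay, with a range of 0% to 45%.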

Compound 3, a percentage reported as inhibition, at one concentration (the size of the read-out at that concentration, not a potency): 78.8%
The estimate for compound 3 lay 68.8 percentage points below the measured number; the whole stated range lies below it.
By their numbers in this assay, from the lowest: compound 2; then compounds 3 and 1 (each within the scatter of the next).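

Filling this position does not in itself cost inhibition: in this assay chloro in place of hydrogen gives a number 4.9 percentage points lower from compound 1 to compound 3 (within the scatter) and leaves the 2,4-dichlorophenyl compound level with the unsubstituted parent. The exchange of fluoro for chloro gives a number 78.8 percentage points higher from compound 2 to compound 3 (beyond the scatter) and so restores nearly all that fluoro lost, which makes the drop specific to fluoro among the groups shown and not a general penalty for substitution here. The data shown give no explanation for this split between two halogens.

On these data alone, whether a methyl, methoxy or bromo group at this position follows chloro or fluoro remains open. Also open, as far as these compounds go, is whether the fluoro drop depends on the 4-chloro group or would recur with a different group in its place.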